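A few compounds are considered here, and "the series" means these few. Any claim that something is new, unique, unknown or untested is made for them only; others in the source may bear on it.

Of the compounds shown here, three built on the same sulfamate core have been measured in an assay on HEK293 cells for inhibition of Steryl-sulfatase (Homo sapiens), tested at 0.1 uM; a higher number here means a stronger effect of the compound at the concentration tested, a lower number a weaker effect. Compound 1 `CCN(Cc1ccccc1)Cc1ccc(CN2CCc3ccc(OS(N)(=O)=O)cc3C2)cc1` gives 1%. Compound 2 `CCN(Cc1ccncc1)c1cccc(C(=O)N2CCc3ccc(OS(N)(=O)=O)cc3C2)c1` gives 33.3%, and compound 3 `CCN(Cc1ccccc1)c1ccc(C(=O)N2CCc3ccc(OS(N)(=O)=O)cc3C2)cc1` gives 66.9%. Among these three numbers compound 2 stands second highest: it lies above compound 1 by a gap beyond the scatter, and below compound 3 by a gap that is also beyond the scatter, with compound 1 the nearer neighbour and compound 3 the further one.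

Compound 4 `CCCN(CCC)c1cccc(C(=O)N2CCc3ccc(OS(N)(=O)=O)cc3C2)c1` has not yet been measured in this assay. It is derived from compound 2 by the change (dipropylamino in place of ethyl((pyridin-4-yl)methyl)amino on an aromatic carbon); the substituent that leaves carries a ring, the one that enters does not.

For the measured compounds named here, no pair of measured compounds differs in only one place, so the size of this kind of change cannot be read from a matched pair. On the present numbers the step from compound 2 to compound 4 is expected to be small or none beyond the scatter, as a number 3.3 percentage points lower from compound 2 to compound 4 (within the scatter), with the direction uncertain. Compound 4 is therefore estimated to give 30% in this assay, within a range from 5% to 60%.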

Compound 4, a percentage reported as inhibition, at one concentration (the size of the read-out at that concentration, not a potency): 8.3%
For compound 4 the middle estimate is 21.7 percentage points above the measured one; the measured number falls inside the stated range.
By their numbers in this assay, from the lowest: compounds 1 and 4 (each within the scatter of the next); then compound 2; then compound 3.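

For the compounds shown here, the first matched pair shows that the aromatic carbon meta to a large group is not indifferent to what it carries: in this assay, placing dipropylamino there in place of ethyl((pyridin-4-yl)methyl)amino gives a number 25 percentage points lower from compound 2 to compound 4 (beyond the scatter). This single exchange removes the six-membered aromatic ring with its hetero atom and also changes the heavy-atom count and the hydrogen-bond acceptor count, so the pair cannot assign the step to any one of these differences. No measurement is available that explains the step.

The compounds shown leave open whether a ring at this place is what matters, since neither piperidin-1-yl nor morpholin-4-yl, each with a ring of a different kind, appears here, and neither does a smaller open-chain group such as diethylamino. They also leave open whether the same exchange would give a step of similar size elsewhere on the aromatic ring, as this one pair is a single case at a single place.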